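The compounds below may be only part of what the source reports. "The series", "measured", "known", "first", "only" and "open" are said of these compounds alone.

Measured compounds in a functional assay on isolated protein for inhibition of Glucose-dependent insulinotropic receptor (Rattus norvegicus), read by HTRF and cAMP accumulation; on this read-out higher numbers stand for an effect only at larger amounts of compound and lower numbers for an effect already at smaller amounts:
compound 1 `Cc1nc(S(C)(=O)=O)ccc1Oc1ncnc(OC2CCN(C(=O)OC(C)C)CC2)c1F` gives 142 nM
compound 2 `Cc1nc(S(C)(=O)=O)ccc1Oc1ncnc(OC2CCN(C(=O)OC(C)(C)C(F)(F)F)CC2)c1F` gives 47.2 nM
compound 3 `Cc1nc(S(C)(=O)=O)ccc1Oc1ncnc(OC2CCN(C(=O)OC(C)(C)CF)CC2)c1F` gives 138 nM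

Compound 3 stands second highest of the three; its number is within the scatter of compound 1 and only compound 2 sits clearly lower. Compound 4 `Cc1nc(S(C)(=O)=O)ccc1Oc1ncnc(OC2CCN(C(=O)O[C@@H](C)C(F)(F)F)CC2)c1F` differs from compound 3 by 1-(trifluoromethyl)ethyl in place of 1-(fluoromethyl)-1-methylethyl on an oxygen next to a carbonyl group. Going by the values given here, two steps bear on this: a 3.0-fold lower number from compound 1 to compound 2 (0.48 log units; beyond the scatter) and a 2.9-fold higher number from compound 2 to compound 3 (0.47 log units; beyond the scatter). Both show the trifluoromethyl-bearing ester giving the lower number, so a modest step downward is expected for compound 4, though the ester now carries one methyl fewer than in compound 2, so the full gain is not assumed. Compound 4 is expected to land at 70 nM (range 30 nM to 160 nM), an estimated step of a 2.0-fold lower number from compound 3 to compound 4 (0.29 log units; within the scatter).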

Compound 4, half-maximal effective concentration: 109 nM
Beside the measured number, compound 4's estimate is 1.6-fold (0.19 log units) below it, within the range that was stated.
By their numbers in this assay, from the lowest: compound 2; then compounds 4, 3 and 1 (each within the scatter of the next).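

On an oxygen next to a carbonyl group, 1-(trifluoromethyl)ethyl does not reproduce the result of 1-methyl-1-(trifluoromethyl)ethyl (a 2.3-fold higher number from compound 2 to compound 4 (0.36 log units; beyond the scatter)). Trifluoromethyl alone therefore does not go with the lower number of compound 2, and compound 4 goes against that reading, staying level with the other two groups (a 1.3-fold lower number from compound 3 to compound 4 (0.10 log units; within the scatter); a 1.3-fold lower number from compound 1 to compound 4 (0.11 log units; within the scatter)). No measurement shown accounts for these steps.

Still open, as far as these compounds go, is whether the defined stereocentre of compound 4 matters, and whether a cyclopropyl group or a longer chain carrying trifluoromethyl at this place would keep the number of compound 2.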